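The source may report more compounds than this note shows. Statements on the series, on what has been measured and on what is new or still open speak of the compounds shown alone.

- Compound 1 `COc1cc(NC(C)CCCNC(=O)NNC(=O)Nc2ccc(C(F)(F)F)cc2)c2ncccc2c1`: 100 nM
- Compound 2 `COc1cc(NC(C)CCCNC(=O)NNC(=O)Nc2cccc(F)c2)c2ncccc2c1`: 150 nM

In a functional assay on MCF7 cells (Homo sapiens) for inhibition, read by MTT assay, with a stated time of 72 h (on this read-out higher numbers stand for weaker inhibition and lower numbers for stronger inhibition), compound 2 gives 150 nM, and compound 1 gives 100 nM, so the two values sit within the scatter of each other. Compound 3 `COc1cc(NC(C)CCCNC(=O)NNC(=O)Nc2cccc(C(F)(F)F)c2)c2ncccc2c1` keeps the whole of compound 2 apart from one change: trifluoromethyl in place of fluoro on an aromatic carbon. Trifluoromethyl takes the place of fluoro on an aromatic carbon, meta to a large group. Within the data shown here, only one measured step bears on this, a 1.5-fold higher number from compound 1 to compound 2 (0.18 log units; within the scatter), where 3-fluorophenyl replaces 4-(trifluoromethyl)phenyl. That swap also involves a trifluoromethyl group and a fluoro group, yet it stays small, so no shift beyond the scatter is expected here. The expected step is a 1.3-fold lower number from compound 2 to compound 3 (0.10 log units; within the scatter). For compound 3 the estimated value is 120 nM, with an expected range from 55 nM to 260 nM.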

Compound 3, half-maximal inhibitory concentration: 190 nM
For compound 3 the middle estimate is 1.6-fold (0.20 log units) below the measured one; the range from low to high includes it.
By their numbers in this assay, from the lowest: compounds 1, 2 and 3 (each within the scatter of the next).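

In this assay the change from fluoro to trifluoromethyl gives a 1.3-fold higher number from compound 2 to compound 3 (0.10 log units; within the scatter) and so does not separate the two groups, even though the entering group has 4 heavy atoms and the leaving group has 1. Compounds 1 and 3 add a comparison of the same group in two named arrangements, and a 1.9-fold higher number from compound 1 to compound 3 (0.28 log units; within the scatter) shows that 3-(trifluoromethyl)phenyl and 4-(trifluoromethyl)phenyl cannot be told apart here either. No measured evidence is available to explain these small steps.

As far as these compounds go, all three compounds carry fluorine on this phenyl ring, so it remains open whether an amine or a carboxylic acid at the same place would give a step beyond the scatter. From the compounds shown here alone, it is also open whether these small steps would hold in other cell lines.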